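Capping the hydroxy group of compound 3

A few compounds are considered here, and "the series" means these few. Any claim that something is new, unique, unknown or untested is made for them only; others in the source may bear on it.

Among the three measured compounds, compound 3 `NS(=O)(=O)OC[C@@H]1C[C@@H](n2nnc3c(N[C@@H]4c5ccccc5C[C@@H]4O)ncnc32)C[C@@H]1O` stands lowest, giving 2.28 nM in an assay on a protein complex for inhibition of NEDD8 activating enzyme (Homo sapiens), read by HTRF, with a stated time of 2 h, in the presence of a further agent that is not named here; a higher number here means a weaker inhibitor, a lower number a stronger inhibitor. Compound 1 `NS(=O)(=O)OC[C@@H]1C[C@@H](n2nnc3c(NCc4ccccc4F)ncnc32)C[C@@H]1O` gives 6.11 nM and compound 2 `NS(=O)(=O)OC[C@@H]1C[C@@H](n2nnc3c(NCCCc4ccccc4)ncnc32)C[C@@H]1O` gives 149 nM; the step of a 2.7-fold lower number from compound 1 to compound 3 (0.43 log units; beyond the scatter) is modest, and the step of a 65-fold lower number from compound 2 to compound 3 (1.82 log units; beyond the scatter) is large. Compound 4 `COCCO[C@H]1Cc2ccccc2[C@H]1Nc1ncnc2c1nnn2[C@@H]1C[C@@H](COS(N)(=O)=O)[C@@H](O)C1` differs from compound 3 by 2-methoxyethyl in place of hydrogen on an oxygen on a saturated carbon. Among the compounds with values here, none of the measured steps touches this oxygen; they all alter the group on the nitrogen, so they bear only indirectly on compound 4. Within the data shown here, with no direct precedent, a small change is expected, a 2.2-fold higher number from compound 3 to compound 4 (0.34 log units; beyond the scatter), toward a slightly higher number if anything. Compound 4 is therefore estimated at 5 nM, with a likely range from 1.5 nM to 20 nM.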

Compound 4, half-maximal inhibitory concentration: 3.56 nM
Estimate against measurement, compound 4: 1.4-fold (0.15 log units) above; the range from low to high includes it.
By their numbers in this assay, from the lowest: compounds 3, 4 and 1 (each within the scatter of the next, the first and the last beyond it); then compound 2.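

Putting 2-methoxyethyl on this oxygen gives a 1.6-fold higher number from compound 3 to compound 4 (0.19 log units; within the scatter) in this assay, so this assay cannot tell the capped compound from the one with the free hydroxy group. Within the data shown here, the earlier steps all altered the group on the nitrogen, and only this step shows that the oxygen on the saturated carbon can carry a chain of this size. Nothing available explains this result. Still open, as far as these compounds go, is whether a longer chain, or a chain ending in an amine or a carboxylic acid, would leave the number as little moved.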